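This account rests on a few compounds, and the source may have more. Where it says the series, first, only, none or still open, it means among the compounds named here.

Compound 1 `O=C(O)C(=O)/C=C(\O)c1ccccc1`: 0%
Compound 2 `COC(=O)C(=N)/C=C(\O)c1ccccc1`: 3%
Compound 3 `COC(=O)C(=N)/C=C(\O)c1ccccc1Cl`: 31%

In an assay for inhibition of kynurenine 3-monooxygenase (Rattus norvegicus), tested at 10 uM (a lower number here means less inhibition, a higher number more inhibition at the concentration tested (going by the name of the read-out)), compound 3 gives 31%, the highest of the three numbers. Among the compounds with values here, the nearest is compound 2 with 3%; the gap between them is the single measured step here, a number 28 percentage points higher from compound 2 to compound 3 (beyond the scatter), and it lies beyond the scatter. Compound 1, with 0%, sits furthest below.

Compound 4 `COC(=O)C(=N)/C=C(\O)c1cccc(Cl)c1Cl` differs from compound 3 in one place: chloro in place of hydrogen on an aromatic carbon. Within the data shown here, the only measured step that bears on this change is a number 28 percentage points higher from compound 2 to compound 3 (beyond the scatter), where a first chloro entered the same ring. That step was modest and upward, so a further chloro on the ring is expected to move the read-out in this assay upward again, though nothing measured shows whether a second chloro adds as much as the first. The expected step is a number 14 percentage points higher from compound 3 to compound 4 (beyond the scatter). Compound 4 is therefore estimated at 45%, within a range from 25% to 65%.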

Compound 4, a percentage reported as inhibition, at one concentration (the size of the read-out at that concentration, not a potency): 33%
The estimate for compound 4 lay 12 percentage points above the measured number; measured number inside the range.
By their numbers in this assay, from the lowest: compounds 1 and 2 (each within the scatter of the next); then compounds 3 and 4 (each within the scatter of the next).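

In this assay, a second chloro on the ring, ortho to a chloro group and meta to a group of 9 heavy atoms, gives a number 2 percentage points higher from compound 3 to compound 4 (within the scatter) and so cannot be told apart from the variation between repeated measurements. The first chloro gave a number 28 percentage points higher from compound 2 to compound 3 (beyond the scatter) and thus a clear rise, so in these compounds the gain from one chloro is not repeated by adding a second at this position. Nothing measured here explains this difference between the two chloro steps. Still open, as far as these compounds go, is whether a different group at this position, such as a methoxy group or an amine, would change the inhibition more than chloro does. Also open, from the compounds shown here alone, is whether the chloro steps would hold with a carboxylic acid in place of the methyl ester.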